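The source may report more compounds than this note shows. Statements on the series, on what has been measured and on what is new or still open speak of the compounds shown alone.

Measured compounds in the series:

compound 1 `CN(C(=O)NC(=O)c1c(F)cccc1F)c1nc(C(F)(F)F)c(C(=O)N/N=C/c2cccc(C(F)(F)F)c2)s1` — 27.9 ug/mL
compound 2 `CN(C(=O)NC(=O)c1ccc(F)c(F)c1)c1nc(C(F)(F)F)c(C(=O)N/N=C/c2ccccc2C(F)(F)F)s1` — 10.4 ug/mL
compound 3 `CN(C(=O)NC(=O)c1ccc(F)c(F)c1)c1nc(C(F)(F)F)c(C(=O)N/N=C/c2cc(C(F)(F)F)cc(C(F)(F)F)c2)s1` — 5.47 ug/mL

In a functional assay on HepG2 cells (Homo sapiens) for inhibition, read by MTT assay, with a stated time of 72 h (a lower number here means a stronger inhibitor, a higher number a weaker inhibitor), compound 3 gives 5.47 ug/mL, the lowest of the three numbers. Compound 2, at 10.4 ug/mL, lies within the scatter of it, so no order between compound 2 and compound 3 can be read. Compound 1, at 27.9 ug/mL, stands beyond the scatter and is the weaker of the three on this assay.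

Compound 4 `CN(C(=O)NC(=O)c1cccc(C(F)(F)F)c1)c1nc(C(F)(F)F)c(C(=O)N/N=C/c2cc(C(F)(F)F)cc(C(F)(F)F)c2)s1` is not yet measured. It differs from compound 3 in one place: 3-(trifluoromethyl)phenyl in place of 3,4-difluorophenyl on a carbonyl carbon. Within the data shown here, no pair of measured compounds isolates this exchange, since the measured compounds change more than one group at a time, so the size of the step cannot be taken from the data. Compound 4 is expected to stay close to compound 3, with a step of a 1.0-fold higher number from compound 3 to compound 4 (0.00 log units; within the scatter) expected to fall within the scatter, in no clear direction. The estimate for compound 4 in this assay is 5.5 ug/mL, with a range from 2.5 ug/mL to 12 ug/mL.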

Compound 4, half-maximal inhibitory concentration: 5.38 ug/mL
Estimate against measurement, compound 4: 1.0-fold (0.01 log units) above, and the stated range covers the measured number.
By their numbers in this assay, from the lowest: compounds 4, 3 and 2 (each within the scatter of the next); then compound 1.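

In this assay, among these compounds, 3-(trifluoromethyl)phenyl in place of 3,4-difluorophenyl on a carbonyl carbon gives a 1.0-fold lower number from compound 3 to compound 4 (0.01 log units; within the scatter), the first exchange confined to one place. At this position, going from 8 to 10 heavy atoms and from two fluorines on the ring to a trifluoromethyl group produces no readable change, so with the rest of the molecule held constant, the two groups cannot be told apart on this read-out. No measurement is available that bears on why this step is flat.

Both groups compared here are fluorine-bearing phenyl rings, so the result says nothing about how an unsubstituted phenyl, a pyridine ring or a simple alkyl chain would read at this carbonyl carbon. From the compounds shown here alone, whether a carboxylic acid or an amine on the phenyl ring would be equally silent also remains open.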